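A few compounds are considered here, and "the series" means these few. Any claim that something is new, unique, unknown or untested is made for them only; others in the source may bear on it.

Measured so far in a functional assay on HCT-116 cells (Homo sapiens) for cytotoxicity, read by sulforhodamine B assay, with a stated time of 24 h; on this read-out higher numbers stand for weaker inhibition and lower numbers for stronger inhibition:
- compound 1 `N/N=C1\C(=O)Nc2ccc(S(=O)(=O)N3CCOCC3)cc21` — 36300 nM
- compound 2 `O=C1Nc2ccc(S(=O)(=O)N3CCOCC3)cc2/C1=N/NC(=O)c1ccccc1` — 28900 nM

Within the data shown here, compound 1 sits at one end of a pair whose two numbers do not separate: the only recorded step, a 1.3-fold lower number from compound 1 to compound 2 (0.10 log units; within the scatter), lies within the scatter, so neither compound 1 nor compound 2 can be called the weaker or stronger of the two in this assay.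

Compound 3 `O=C1Nc2ccc(S(=O)(=O)N3CCOCC3)cc2/C1=N/NS(=O)(=O)c1ccccc1` differs from compound 1 by phenylsulfonyl in place of hydrogen on an amine nitrogen. Among the measured compounds shown here, the one step that bears on this is the substitution at the same amine nitrogen, a 1.3-fold lower number from compound 1 to compound 2 (0.10 log units; within the scatter), where benzoyl replaced hydrogen without moving the number beyond the scatter. The present change, phenylsulfonyl in place of hydrogen on that nitrogen, is the same kind of exchange and the same nitrogen, so the expectation is that it behaves alike: no step beyond the scatter in this assay, expected as a 1.2-fold lower number from compound 1 to compound 3 (0.08 log units; within the scatter). For the measured compounds named here, with only one relevant step, this is a thin basis, and the range is drawn wide.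

Compound 3 is therefore estimated at 30000 nM in this assay, expected to fall between 12000 nM and 75000 nM.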

Compound 3, half-maximal inhibitory concentration: 13300 nM
Estimate against measurement, compound 3: 2.3-fold (0.35 log units) above; measured number inside the range.
By their numbers in this assay, from the lowest: compound 3; then compounds 2 and 1 (each within the scatter of the next).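

At the amine nitrogen, phenylsulfonyl is the only substitution shown that separates from the scatter in this assay, with a 2.7-fold lower number from compound 1 to compound 3 (0.44 log units; beyond the scatter) against hydrogen, whereas benzoyl on the same nitrogen did not separate. The direct exchange of the two groups also reads beyond the scatter, with a 2.2-fold lower number from compound 2 to compound 3 (0.34 log units; beyond the scatter) in this assay, so at this position the outcome depends on which group enters and not merely on hydrogen being replaced, although both steps are modest. Nothing on hand explains why phenylsulfonyl and benzoyl differ here.

From the compounds shown here alone, whether the lower number goes with the sulfonyl link or with the phenyl ring stays open, and a methylsulfonyl or an acetyl group on this nitrogen, or a phenylsulfonyl carrying a methoxy group or a chlorine on its ring, would help to tell these apart. Going by these compounds, the shared core is the same in all three compounds, so how these steps would read with a different group elsewhere on the core also remains open.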